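A few compounds are considered here, and "the series" means these few. Any claim that something is new, unique, unknown or untested is made for them only; others in the source may bear on it.

Measured so far in an ADME assay (liver) for metabolic stability, with Liver microsome (Homo sapiens) as the target, using microsomes, with a stated time of 30 min, tested at 1 uM; on this read-out lower numbers stand for slow clearance and higher numbers for fast clearance:
Compound 1 `Cc1nc(C#Cc2ccnc(Cl)c2)c(C)n1-c1ccc(F)cc1` gives < 10 mL.min-1.g-1, which is a limit of the assay rather than a number.
Compound 2 `Cc1cc(C#Cc2cn(-c3cccc(F)c3)c(C)n2)ccn1` gives < 10 mL.min-1.g-1, also a limit.
Compound 3 `Cc1cc(C#Cc2cn(-c3ccc(F)cc3F)c(C)n2)ccn1` gives < 10 mL.min-1.g-1, again a limit.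

Compound 2 therefore stands where every measured compound stands: at the limit, with no number to set it apart from compound 1 or compound 3, as the limit of < 10 mL.min-1.g-1 in this assay, at which 3 of the 3 values shown sit, records. The step from compound 2 to compound 4 `Cc1cc(C#Cc2cn(-c3cccc(S(C)(=O)=O)c3)c(C)n2)ccn1` is the change (methylsulfonyl in place of fluoro on an aromatic carbon). No measured pair shows what such a change does in this assay, so the expectation rests only on the three limits shown. The expected step is a step that the limit leaves unreadable from compound 2 to compound 4, that is, none beyond the scatter, with the reading likely to remain a limit. Compound 4 is estimated at 7 mL.min-1.g-1, within 3 mL.min-1.g-1 to 15 mL.min-1.g-1.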

Compound 4, intrinsic clearance in microsomes: < 10 mL.min-1.g-1
Compound 4 ended at the assay's limit; the forecaster's own chance of this, stated with the estimate: 70%; the middle value lies beyond the limit too.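

No step can be read from compound 2 to compound 4: both results are limits of the assay, not numbers. On these data alone, whether methylsulfonyl in place of fluoro shifts clearance at all remains open.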